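A few compounds are considered here, and "the series" means these few. Any claim that something is new, unique, unknown or untested is made for them only; others in the source may bear on it.

Working notes on the bile acid receptor series

Three compounds carry the shared core of compound 3, `CC(C)c1onc(-c2c(Cl)cccc2Cl)c1COc1ccc(C(=O)Nc2cccc(C(=O)O)c2)c(Cl)c1`, a dichlorophenyl-isoxazole ether linked to an aryl group. In a functional assay on HEK293 cells for agonist activity at Bile acid receptor (Homo sapiens) (a higher number here means that more compound is needed for the effect, a lower number that less compound is needed), compound 3 gives 3000 nM, the lowest of the three numbers recorded. Compound 1, `CCCNC(=O)c1cccc(/C=C/c2ccc(OCc3c(-c4c(Cl)cccc4Cl)noc3C(C)C)cc2Cl)c1`, gives 9000 nM in this assay, and compound 2, `CC(C)c1onc(-c2c(Cl)cccc2Cl)c1COc1ccc(/C=C/c2cccc(C(=O)N(Cc3ccccc3)Cc3ccccc3)c2)c(Cl)c1`, gives 35100 nM; the two values of compound 1 and compound 2 stand well apart from each other, and both stand above compound 3. Both of these carry a stilbene linker rather than the anilide of compound 3, so the three numbers come from two linker types and no single-point comparison is available among the measured set.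

For the measured compounds named here, compound 4, `CCCN(C(=O)c1ccc(OCc2c(-c3c(Cl)cccc3Cl)noc2C(C)C)cc1Cl)c1cccc(C(=O)O)c1`, is the only one-point variation of compound 3 recorded: propyl in place of hydrogen on an amide-type nitrogen. The acid-bearing ring and the rest of the molecule are unchanged.

Going by the values given here, no measured pair shows what this change does. With the anilide hydrogen gone, the step from compound 3 to compound 4 in this assay is expected to run toward a higher number, of modest size, possibly reaching beyond the scatter, a 2.3-fold higher number from compound 3 to compound 4 (0.37 log units; beyond the scatter). On that basis compound 4 is estimated at 7000 nM in this assay, with a range from 2000 nM to 25000 nM.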

Compound 4, half-maximal effective concentration: 2100 nM
For compound 4 the middle estimate is 3.3-fold (0.52 log units) above the measured one; the measured number falls inside the stated range.
By their numbers in this assay, from the lowest: compounds 4 and 3 (each within the scatter of the next); then compound 1; then compound 2.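

In this assay, propyl in place of hydrogen on the amide-type nitrogen gives a 1.4-fold lower number from compound 3 to compound 4 (0.15 log units; within the scatter), so this change does not separate the two compounds. For the compounds shown here, this is the first pair that differs in one place, and it shows that the amide hydrogen is not required for a number in this range: with the propyl group on the nitrogen and the acid-bearing ring and the rest of the molecule unchanged, the reading stays within the scatter of the parent. The data at hand offer nothing that explains this outcome.

Going by these compounds, one step at one position says little about how far this nitrogen tolerates change, so it remains open whether a methyl group, a longer chain such as hexyl, or a chain ending in an amine would also stay within the scatter of the parent. Also open, on these data alone, is whether the propyl group would leave the number just as undisturbed if a tetrazole or a primary amide took the place of the carboxylic acid on the same ring.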